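The source may hold more compounds than are shown below. What is called first, only, known or untested is meant among the compounds shown, and "the series" means these compounds.

Compound 3 `Cc1cccc(-n2nncc2CN2C(=O)C3(C(C#N)=C(N)Oc4c(N)cc5nc6ccccc6nc5c43)c3ccccc32)c1` is the measured starting point. In a functional assay on HepG2 cells (Homo sapiens) for antiproliferative activity, read by MTT assay, with a stated time of 48 h (on this read-out higher numbers stand for weaker inhibition and lower numbers for stronger inhibition), compound 3 gives only a limit of the assay, > 50000 nM. Two related compounds also stop at a limit. Compound 1 `N#CC1=C(N)Oc2c(c3nc4ccccc4nc3c3ccccc23)C12C(=O)N(Cc1cnnn1-c1ccc(F)cc1)c1ccccc12` gives a limit in this assay, > 50000 nM. Compound 2 `N#CC1=C(N)Oc2c(c3nc4ccccc4nc3c3ccccc23)C12C(=O)N(Cc1cnnn1-c1ccc(F)c(Cl)c1)c1ccccc12` gives a limit as well, > 50000 nM. For the measured compounds named here, the single measured step with one change, a step that the two limits leave unreadable from compound 1 to compound 2, cannot be read in size, since both of its ends are limits. All three values sit at the same place, (the limit of > 50000 nM in this assay, at which 3 of the 3 values shown sit).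

Compound 4 `Cc1ccc(Cl)cc1-n1nncc1CN1C(=O)C2(C(C#N)=C(N)Oc3c(N)cc4nc5ccccc5nc4c32)c2ccccc21` differs from compound 3 in one place: 5-chloro-2-methylphenyl in place of 3-methylphenyl on an aromatic nitrogen. Going by the values given here, the only measured step that involves a chlorine replacing a hydrogen on an aromatic carbon, a step that the two limits leave unreadable from compound 1 to compound 2, shows neither direction nor size, so it gives no reason to expect a reading away from the limit. The expected step from compound 3, a step that the limit leaves unreadable from compound 3 to compound 4, is estimated to be none beyond the scatter. Compound 4 is therefore expected to give about 80000 nM, with a range from 30000 nM to 300000 nM.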

Compound 4, half-maximal inhibitory concentration: 17300 nM
Compound 4: middle estimate off by 4.6-fold (0.67 log units), on the high side; measured number outside the range, below it.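

In this assay, for the compounds shown here, 5-chloro-2-methylphenyl in place of 3-methylphenyl on the aromatic nitrogen gives the first readable step: an at least 2.8-fold lower number from compound 3 to compound 4 (0.46 log units; beyond the scatter). As far as these compounds go, the earlier step from compound 1 to compound 2 cannot be read, and although one end of this new step is also a limit, so that its full size stays unknown, it shows that changing the ring on this nitrogen can move the read-out. Compound 4 is the only compound shown that comes off that limit: the limit of > 50000 nM in this assay, at which 3 of the 4 values shown sit.

This single swap both adds a chlorine and changes where the methyl sits, so the compounds shown leave open which of the two matters, or whether both are needed. Also open, from the compounds shown here alone, is how other groups on this ring, such as an amine or a carboxylic acid, would behave.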